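The compounds below may be only part of what the source reports. "The series", "measured", "known", "first", "only" and "open" are said of these compounds alone.

Three compounds have so far been run through an assay on cells for inhibition of Indoleamine 2,3-dioxygenase 1 (Homo sapiens), read by HPLC, with a stated time of 20 min; on this read-out lower numbers stand for stronger inhibition and higher numbers for weaker inhibition. Compound 1 `Cn1cncc1-c1cc(Cl)ccc1O` gives 17000 nM in this assay. Compound 2 `Nc1ccccc1-c1nnc[nH]1` gives 2000 nM in this assay. Compound 3 `Oc1ccccc1-c1nnn[nH]1` gives 700000 nM in this assay, the highest of the three numbers, which here means the weakest inhibition; its gap to compound 1, the nearest of the others, is well beyond the usual scatter, and its gap to compound 2 is wider still.

The next compound is compound 4 `Nc1ccccc1-c1nnn[nH]1`, which has not yet been measured. Compared with compound 3 the change is amino in place of hydroxy on an aromatic carbon. For the measured compounds named here, no two measured compounds differ in just this one place, so the size of this step cannot simply be read off from an earlier pair. Compound 2 does carry the amino group on its six-membered ring and gives 2000 nM, but it also carries a different second ring, so it is only a loose pointer. On that basis the step from compound 3 to compound 4 is expected to be a clear one toward stronger inhibition, roughly a 14-fold lower number from compound 3 to compound 4 (1.15 log units; beyond the scatter) in this assay. Compound 4 is therefore estimated at 50000 nM in this assay, with a plausible range from 5000 nM to 400000 nM.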

Compound 4, half-maximal inhibitory concentration: 5800 nM
Compound 4: the middle estimate sits 8.6-fold (0.94 log units) above what was measured; measured number inside the range.
By their numbers in this assay, from the lowest: compound 2; then compound 4; then compound 1; then compound 3.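

In this assay, putting amino in place of hydroxy on this aromatic carbon gives a 120-fold lower number from compound 3 to compound 4 (2.08 log units; beyond the scatter), a large step toward stronger inhibition and well beyond the usual scatter. For the compounds shown here, this is the first direct reading at this position, as the earlier compounds offered no pair differing in just one place, and it shows that the number can move sharply when only one heavy atom changes, an oxygen for a nitrogen. The two groups have the same counts of hydrogen-bond donors and acceptors and neither carries a net charge, so those counts do not separate them, and no measurement available here accounts for the size of the step.

The compounds shown leave open how other groups on this carbon, such as methylamino, methoxy or a fluorine atom, would compare with amino in this assay. They also leave open whether the same swap would give a step of similar size on the core of compound 1, which carries a hydroxy group of its own.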